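Aryl exchange on the shared core at the tested concentration

A few compounds are considered here, and "the series" means these few. Any claim that something is new, unique, unknown or untested is made for them only; others in the source may bear on it.

Compound 2 `O=Cc1ccc(-c2cn3ccnc3c(-c3ccc4ncn(Cc5ccccc5)c4c3)n2)cc1` stands lowest of the two numbers in a functional assay on SNB-19 cells (Homo sapiens) for inhibition, read by sulforhodamine B assay, with a stated time of 48 h, tested at 10 uM (on this read-out lower numbers stand for less inhibition and higher numbers for more inhibition at the one concentration tested (going by the name of the read-out)), though within the scatter of its neighbour, giving 14.4% there; compound 1 `CCc1ccc(-c2cn3ccnc3c(-c3ccc4ncn(Cc5ccccc5)c4c3)n2)cc1` gives 20.9% in this assay. Going by the values given here, the only measured step, a number 6.5 percentage points lower from compound 1 to compound 2 (within the scatter), stays within the scatter, so nothing so far moves beyond it. Compound 3 `c1ccc(Cn2cnc3ccc(-c4nc(-c5cccc6ccccc56)cn5ccnc45)cc32)cc1` differs from compound 2 by naphthalen-1-yl in place of 4-formylphenyl on an aromatic carbon. This exchanges the entire attached group rather than one substituent on it, so the measured step bears on it only loosely; no step beyond the scatter is expected in this assay. Compound 3 is therefore estimated at 18%, within 4% to 36%, an expected step of a number 3.6 percentage points higher from compound 2 to compound 3 (within the scatter).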

Compound 3, a percentage reported as inhibition, at one concentration (the size of the read-out at that concentration, not a potency): 5.12%
Beside the measured number, compound 3's estimate is 12.9 percentage points above it; the range from low to high includes it.
By their numbers in this assay, from the lowest: compounds 3, 2 and 1 (each within the scatter of the next, the first and the last beyond it).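

In this assay this position on the shared core gives its first step beyond the scatter, a number 15.8 percentage points lower from compound 1 to compound 3 (beyond the scatter) with naphthalen-1-yl replacing 4-ethylphenyl. Against 4-formylphenyl the same group gives a number 9.3 percentage points lower from compound 2 to compound 3 (within the scatter) and stays within the scatter, so the exchange registers against only one of the two substituted phenyl groups. No measurement on hand accounts for this difference.

Open, as far as these compounds go, is how the number responds to an amine or a carboxylic acid on the phenyl ring, or to a longer chain in place of ethyl.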